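Replacing 2,5-dimethylfuran-3-yl with thiophen-2-yl on a carbonyl carbon

The compounds below may be only part of what the source reports. "The series", "measured", "known", "first", "only" and "open" are said of these compounds alone.

Compound 1 `COc1ccc(/C=C/C=C/C(=O)c2ccccc2)cc1` and compound 2 `COc1ccc(/C=C/C=C/C(=O)c2cc(C)oc2C)cc1` were both tested in an ADME assay on RAW264.7 cells (Mus musculus) for cytotoxicity, read by MTT assay; on this read-out lower numbers stand for stronger inhibition and higher numbers for weaker inhibition. Compound 1 gives > 100000 nM, which is a limit of the assay and not a number. Compound 2 gives > 100000 nM, which is also a limit. Compound 2 therefore stands at the limit of > 100000 nM in this assay, at which 2 of the 2 values shown sit. Among the compounds with values here, the only measured step is a step that the two limits leave unreadable from compound 1 to compound 2, so it offers no size to carry forward. Compound 3 `COc1ccc(/C=C/C=C/C(=O)c2cccs2)cc1` has thiophen-2-yl in place of 2,5-dimethylfuran-3-yl on a carbonyl carbon. The expected change is a number no higher from compound 2 to compound 3 (the limit leaves the size open), and nothing beyond the scatter is expected. For compound 3 the estimated value is 100000 nM, with an expected range of 40000 nM to 250000 nM.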

Compound 3, half-maximal inhibitory concentration: 68500 nM
Estimate against measurement, compound 3: 1.5-fold (0.16 log units) above; the measured number falls inside the stated range.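

Thiophen-2-yl on a carbonyl carbon gives the only number in this assay that is not a limit: compound 3 gives 68500 nM. Read against the two limits, the change is an at least 1.4-fold lower number from compound 2 to compound 3 (0.16 log units; that floor lies within the scatter) and an at least 1.4-fold lower number from compound 1 to compound 3 (0.16 log units; that floor lies within the scatter). Each step is only a floor, so the true size remains open, and the other two compounds give no exact value: the limit of > 100000 nM in this assay, at which 2 of the 3 values shown sit.

The compounds shown do not tell how far compound 3 truly lies from compound 1 or compound 2. They also leave open how an aliphatic amine or a carboxylic acid-bearing group would read on this carbonyl carbon.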